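The source may report more compounds than this note shows. Statements on the series, on what has been measured and on what is new or still open speak of the compounds shown alone.

Measured in an ADME assay (liver) for metabolic stability, with Liver microsome (Rattus norvegicus) as the target, using microsomes and NADPH, with a stated time of 30 min; on this read-out lower numbers stand for slow clearance and higher numbers for fast clearance:
- compound 1 `CC#C[C@H]1CN(S(=O)(=O)c2ccc(N)nc2)CCN1c1ccc([C@@](O)(CO)C(F)(F)F)cc1`: 53 mL.min-1.g-1
- compound 2 `CC#C[C@H]1CN(S(=O)(=O)c2ccc(N)nc2)CCN1c1ccc(S(=O)(=NC)C(F)(F)F)cc1`: 257 mL.min-1.g-1

Compound 2, at 257 mL.min-1.g-1, holds the higher of the two numbers in this assay, and compound 1 gives 53 mL.min-1.g-1. Compound 3 `C#CCC(O)(c1ccc(N2CCN(S(=O)(=O)c3ccc(N)nc3)C[C@@H]2C#CC)cc1)C(F)(F)F` has not yet been measured. It differs from compound 2 at one place: a group of 9 heavy atoms (5 carbon, 1 oxygen, 3 fluorine; no ring) in place of a group of 8 heavy atoms (2 carbon, 1 nitrogen, 1 oxygen, 3 fluorine, 1 sulfur; no ring), on an aromatic carbon. In words, this is a group of 9 heavy atoms (5 carbon, 1 oxygen, 3 fluorine; no ring) in place of a group of 8 heavy atoms (2 carbon, 1 nitrogen, 1 oxygen, 3 fluorine, 1 sulfur; no ring), on an aromatic carbon.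

Among the measured compounds shown here, only one measured step bears on this, and only indirectly: a 4.8-fold higher number from compound 1 to compound 2 (0.69 log units; beyond the scatter). For the measured compounds named here, that step leaves the same group of compound 2 at the same place, but the group at the other end differs from the one in compound 3. The entering group resembles the group of compound 1 in holding carbon, oxygen and fluorine with no sulfur or nitrogen. A fall is therefore expected, probably smaller than the measured step, and the expected change is a 2.2-fold lower number from compound 2 to compound 3 (0.35 log units; beyond the scatter). Compound 3 is estimated at 115 mL.min-1.g-1, with an expected range from 50 mL.min-1.g-1 to 260 mL.min-1.g-1.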

Compound 3, intrinsic clearance in microsomes: 59 mL.min-1.g-1
Estimate against measurement, compound 3: 1.9-fold (0.29 log units) above; low and high end bracket the measured number.
By their numbers in this assay, from the lowest: compounds 1 and 3 (each within the scatter of the next); then compound 2.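

In this assay, replacing the sulfur-bearing group of compound 2 with the group of 9 heavy atoms (5 carbon, 1 oxygen, 3 fluorine; no ring), on an aromatic carbon para to a large group, gives a 4.4-fold lower number from compound 2 to compound 3 (0.64 log units; beyond the scatter), so a second group without sulfur or nitrogen now stands apart from compound 2 at this position. Compared with the carbon, oxygen and fluorine group of compound 1, the entering group gives a 1.1-fold higher number from compound 1 to compound 3 (0.05 log units; within the scatter), so these two groups cannot be told apart on this read-out, even though the entering group carries 1 triple bond outside aromatic rings. Nothing measured here accounts for the gap between these groups and the group of compound 2.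

Going by these compounds, it remains open whether the higher number of compound 2 goes with the whole sulfur-bearing group or only part of it, which a methyl sulfone or a plain trifluoromethyl group at this position could help to separate. On these data alone, it is also open whether the chain with the triple bond matters at all, a question that a saturated propyl chain in its place could address.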